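A few compounds are considered here, and "the series" means these few. Any claim that something is new, unique, unknown or untested is made for them only; others in the source may bear on it.

Measured so far:
Compound 1 `CCC(C)C(=O)N1CCN(c2nc(=O)c3cc(C(F)(F)F)cc([N+](=O)[O-])c3s2)CC1` — 104 ug/mL
Compound 2 `O=C(c1ccc(F)cc1)N1CCN(c2nc(=O)c3cc(C(F)(F)F)cc([N+](=O)[O-])c3s2)CC1` — 1.69 ug/mL

In a physicochemical assay for solubility, read by HPLC (on this read-out higher numbers stand for higher solubility and lower numbers for lower solubility), compound 2 stands lowest of the two numbers; its nearest neighbour is compound 1, and the step of a 62-fold lower number from compound 1 to compound 2 (1.79 log units; beyond the scatter) was large and beyond the scatter. Compound 3 `CCCC(=O)N1CCN(c2nc(=O)c3cc(C(F)(F)F)cc([N+](=O)[O-])c3s2)CC1` differs from compound 2 by propyl in place of 4-fluorophenyl on a carbonyl carbon. Within the data shown here, the only step that bears on this change is the one from compound 1 to compound 2, which swapped an alkyl group for the same 4-fluorophenyl group and cut the solubility sharply; compound 3 reverses that kind of change with a shorter alkyl group. A large rise is therefore expected, a 71-fold higher number from compound 2 to compound 3 (1.85 log units; beyond the scatter), and compound 3 is estimated at 120 ug/mL, within 40 ug/mL to 350 ug/mL.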

Compound 3, solubility: 2.46 ug/mL
Estimate against measurement, compound 3: 49-fold (1.69 log units) above; the measured number lies below the stated range.
By their numbers in this assay, from the lowest: compounds 2 and 3 (each within the scatter of the next); then compound 1.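

In this assay, propyl in place of 4-fluorophenyl on a carbonyl carbon gives a 1.5-fold higher number from compound 2 to compound 3 (0.16 log units; within the scatter) and so separates these two compounds by nothing beyond the scatter. The large step lies instead in a single methyl on the saturated chain carbon bound to a carbonyl carbon: hydrogen in its place gives a 42-fold lower number from compound 1 to compound 3 (1.63 log units; beyond the scatter) and shows that, among these three compounds, an alkyl group at this place does not alone go with the high number. From the compounds shown here alone, whether that number holds for isopropyl, tert-butyl, a longer chain or a chain carrying an amine stays open. Nothing given here bears on the reason for this gap.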